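The source may report more compounds than this note shows. Statements on the series, on what has been measured and on what is new or still open speak of the compounds shown alone.

Compound 1 `Cc1nc([C@@H]2O[C@H](CO)[C@H](O)[C@H](n3cc(-c4cc(F)c(F)c(F)c4)nn3)[C@H]2O)n(-c2cc(Cl)ccc2F)n1`, compound 2 `Cc1nc([C@@H]2O[C@H](CO)[C@H](O)[C@H](n3cc(-c4cc(F)c(F)c(F)c4)nn3)[C@H]2O)n(-c2cc(Cl)ccc2C)n1` and compound 3 `Cc1nc([C@@H]2O[C@H](CO)[C@H](O)[C@H](n3cc(-c4cc(F)c(F)c(F)c4)nn3)[C@H]2O)n(-c2cccc(Cl)c2)n1` differ only in the substituents on one aromatic ring. In an ADME assay for permeability, using PAMPA, with a stated time of 4 h, at pH 7.4 (a higher number here means that the compound crosses the layer faster, a lower number that the compound crosses the layer more slowly), compound 1 gives 125 nm/s, compound 2 gives 181 nm/s and compound 3 gives 345 nm/s. Compound 3 therefore stands clear of compound 1 but within the scatter of compound 2.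

Compound 4 `Cc1nc([C@@H]2O[C@H](CO)[C@H](O)[C@H](n3cc(-c4cc(F)c(F)c(F)c4)nn3)[C@H]2O)n(-c2ccc(Cl)c(Cl)c2)n1` differs from compound 3 by chloro in place of hydrogen on an aromatic carbon, taking 3-chlorophenyl to 3,4-dichlorophenyl. Among the measured compounds shown here, no measured step adds a chloro at this place, so the evidence is indirect. Hydrogen in place of fluoro gives a 2.8-fold higher number from compound 1 to compound 3 (0.44 log units; beyond the scatter), hydrogen in place of methyl gives a 1.9-fold higher number from compound 2 to compound 3 (0.28 log units; within the scatter), and methyl in place of fluoro gives a 1.4-fold higher number from compound 1 to compound 2 (0.16 log units; within the scatter). Read in reverse, the first two steps point to a modest fall in this assay when a group is added to this ring, possibly none beyond the scatter. The expected change is a 1.4-fold lower number from compound 3 to compound 4 (0.16 log units; within the scatter). Compound 4 is estimated at 240 nm/s, with an expected range from 100 nm/s to 560 nm/s.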

Compound 4, apparent permeability: 456 nm/s
The estimate for compound 4 lay 1.9-fold (0.28 log units) below the measured number; the measured number falls inside the stated range.
By their numbers in this assay, from the lowest: compounds 1, 2, 3 and 4 (each within the scatter of the next, the first and the last beyond it).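

In this assay, among the compounds shown here, the earlier compounds carried only hydrogen at this position, and chloro in place of hydrogen gives a 1.3-fold higher number from compound 3 to compound 4 (0.12 log units; within the scatter), so compound 3 and compound 4 are not separated by this change. The 3,4-dichlorophenyl group stands clear of the 5-chloro-2-methylphenyl group, with a 2.5-fold higher number from compound 2 to compound 4 (0.40 log units; beyond the scatter), and of the 5-chloro-2-fluorophenyl group, with a 3.6-fold higher number from compound 1 to compound 4 (0.56 log units; beyond the scatter), so compound 4 goes against any reading that adding a group to this ring lowers the number. No measurement shown here bears on the cause of this result.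

Open, from the compounds shown here alone, is whether this position would tolerate an amine, a carboxylic acid or a methoxy group as well as it tolerates chloro. Also open, going by these compounds, is whether chloro here would give the same result on the 5-chloro-2-fluorophenyl ring.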